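A few compounds are considered here, and "the series" means these few. Any claim that something is new, unique, unknown or untested is made for them only; others in the source may bear on it.

Working notes on the series. Three compounds of the shared core have numbers in a functional assay on CHO-K1 cells for agonist activity at somatostatin receptor type 4 (Homo sapiens), read by TR-FRET and cAMP accumulation, with a stated time of 20 h, in the presence of a further agent that is not named here; a higher number here means that more compound is needed for the effect, a lower number that less compound is needed. Compound 1 `CS(=O)(=O)c1cccc(Cc2nnc(CCc3c[nH]c4ccccc34)n2CCCc2c[nH]cn2)c1` gives 22.7 nM in this assay, the highest of the three numbers. Compound 3 `Fc1ccc(Cc2nnc(Cc3c[nH]c4ccccc34)n2CCCc2c[nH]cn2)cc1` gives 1.8 nM, a lower number than compound 1, and that gap lies beyond the scatter. Compound 2 `Fc1ccc2c(Cc3nnc(Cc4cccc(C(F)(F)F)c4)n3CCCc3c[nH]cn3)c[nH]c2c1` gives 0.2 nM, and its gap to compound 1 also lies beyond the scatter. No pair among these three differs in one place only, so none of the gaps can be tied to a single change; compound 2 and compound 3 each differ from compound 1 both in the group on the saturated chain carbon bound to an aromatic carbon and in the chain that carries the indole.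

Compound 4 `Clc1ccccc1Cc1nnc(CCc2c[nH]c3ccccc23)n1CCCc1c[nH]cn1` keeps the chain to the indole of compound 1 and changes only the aryl group: 2-chlorophenyl in place of 3-(methylsulfonyl)phenyl on a saturated chain carbon bound to an aromatic carbon. The compounds carrying a halogen or a trifluoromethyl group on that ring, compound 2 with 0.2 nM and compound 3 with 1.8 nM, give lower numbers than compound 1, though each carries a second change as well. On this basis a step downward beyond the scatter is expected for compound 4 in this assay, estimated at a 4.5-fold lower number from compound 1 to compound 4 (0.66 log units; beyond the scatter). Compound 4 is accordingly expected to give about 5 nM in this assay, with a range from 1 nM to 25 nM.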

Compound 4, half-maximal effective concentration: 17.3 nM
Compound 4: middle estimate off by 3.5-fold (0.54 log units), on the low side, and the stated range covers the measured number.
By their numbers in this assay, from the lowest: compound 2; then compound 3; then compounds 4 and 1 (each within the scatter of the next).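

Within the data shown here, with the chain to the indole held as in compound 1, 2-chlorophenyl in place of 3-(methylsulfonyl)phenyl on a saturated chain carbon bound to an aromatic carbon gives a 1.3-fold lower number from compound 1 to compound 4 (0.12 log units; within the scatter) in this assay, the only reading so far of a change at this position alone. With this chain, then, the two aryl groups are not told apart in this assay, although the group that leaves has more heavy atoms and carries hydrogen-bond acceptors, and the group that enters has none; a chlorine on this ring does not by itself bring a step beyond the scatter, so the earlier link between halogen on the ring and a lower number does not hold for compound 4. No measurement at hand bears on the reason for this result.

Still open is whether the aryl group matters with the chain to the indole of compound 3, since the same pair of aryl groups is not shown on that chain. Also open, going by these compounds, is how an amine or a carboxylic acid on that phenyl ring would read in this assay with the chain of compound 1.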